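The source may hold more compounds than are shown below. What is called first, only, known or untested is meant among the compounds shown, and "the series" means these compounds.

Measured in a physicochemical assay for acid dissociation, tested at 10 mM:
- compound 1 `Cc1nn(-c2ccccc2)c(S)c1C(=O)c1ccccc1`: 2.9
- compound 2 `Cc1cc(COc2cc(C)nn2-c2ccc([N+](=O)[O-])cc2)n(-c2ccccc2)n1`: 2

Only these two compounds have been measured. Compound 2, at 2, holds the lower number of the pair, and its gap to compound 1 lies beyond the usual scatter of repeated measurements.

The next compound is compound 3 `Cc1cc(OCc2cc(C)nn2-c2ccccc2)[nH]n1`, which has not yet been measured. Its structure differs from that of compound 2 in one place: hydrogen in place of 4-nitrophenyl on an aromatic nitrogen. In words, hydrogen stands in place of 4-nitrophenyl on an aromatic nitrogen of a five-membered aromatic ring with 2 nitrogen.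

For the measured compounds named here, no measured pair shows this change, so any expectation is loose. Going by the values given here, the only guide is compound 1, which carries no 4-nitrophenyl and stands at 2.9. A rise beyond the scatter is therefore expected in this assay, with the estimated step being a number 1.00 log units higher from compound 2 to compound 3 (beyond the scatter). For compound 3 the expected value is 3, with an estimated range from 2.2 to 4.2.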

Compound 3, acid dissociation constant: 2.4
For compound 3 the middle estimate is 0.60 log units above the measured one; the range from low to high includes it.
By their numbers in this assay, from the lowest: compound 2; then compound 3; then compound 1.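

Hydrogen in place of 4-nitrophenyl is the first change in a single place seen in this assay, and it gives a number 0.40 log units higher from compound 2 to compound 3 (beyond the scatter), a modest step. It shows that the read-out responds to what is carried at this position, on an aromatic nitrogen of a five-membered aromatic ring with 2 nitrogen, something that compound 1 and compound 2 could not show, as they differ in more than one place. Nothing measured here bears on why the number moves with this change.

The compounds shown leave open whether the step belongs to the 4-nitrophenyl group as a whole or to its nitro group alone, and a plain phenyl group at this position, set against compound 2 and compound 3, would separate the two. They also leave open how far the number would move with other groups on this nitrogen, such as a 4-aminophenyl group, a 4-carboxyphenyl group or a short ethyl chain, and whether the direction of the step would hold for any of them.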